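A Hydroxy Group Added to Compound 1

A few compounds are considered here, and "the series" means these few. Any claim that something is new, unique, unknown or untested is made for them only; others in the source may bear on it.

In an ADME assay for metabolic stability, at pH 3.0 (on this read-out higher numbers stand for a longer-lived compound and lower numbers for a shorter-lived compound), compound 1 `Cc1cccc2c1OP(=O)(OCC1CCC(n3cnc4c(O)ncnc43)O1)OC2` gives 3 h, the lowest of three numbers and beyond the scatter from both others. Compound 2 `Cc1cc(C)c2c(c1)COP(=O)(OCC1CCC(n3cnc4c(N)ncnc43)O1)O2` gives 10.3 h, and compound 3 `Nc1ncnc2c1ncn2C1CCC(COP2(=O)OCc3ccccc3O2)O1` gives 12.9 h. No two of these differ in only one place, so no single change has yet been measured. Compound 4 `Cc1cccc2c1OP(=O)(OCC1CC(O)C(n3cnc4c(O)ncnc43)O1)OC2` carries one change from compound 1: hydroxy in place of hydrogen on a saturated ring carbon. A modest rise is expected, a 2.7-fold higher number from compound 1 to compound 4 (0.43 log units; beyond the scatter), though this is only a loose expectation. Going by the values given here, the highest number so far, from compound 3 at 12.9 h, serves as a rough guide to the upper end. For compound 4 the estimated half-life is 8 h, with an expected range from 3 h to 24 h.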

Compound 4, half-life in the ADME assay: 0.04 h
The estimate for compound 4 lay 200-fold (2.30 log units) above the measured number; the whole stated range lies above it.
By their numbers in the ADME assay, from the lowest: compound 4; then compound 1; then compounds 2 and 3 (each within the scatter of the next).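

On the ADME assay hydroxy in place of hydrogen on a saturated ring carbon brings a 75-fold lower number from compound 1 to compound 4 (1.88 log units; beyond the scatter), with compound 1 at 3 h and compound 4 at 0.04 h, and shows that one small change at this position, next to the ring atom that bears a large group, can shorten the half-life sharply. On a physicochemical assay for lipophilicity (on this read-out higher numbers stand for higher lipophilicity and lower numbers for lower lipophilicity), the same change gives a number 0.06 log units lower from compound 1 to compound 4 (within the scatter), with compound 1 at 0.14 and compound 4 at 0.078, and so leaves that read-out within the scatter. Nothing measured here explains the drop in half-life.

From the compounds shown here alone, whether another group at this position, such as an amine or a methoxy group, would bring the same loss remains open. So does whether the same change would act alike on compound 2 and compound 3.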